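This account rests on a few compounds, and the source may have more. Where it says the series, first, only, none or still open, it means among the compounds named here.

Measured compounds:
compound 1, `CCOC(=O)C1=C(C)NC(=S)NC1c1ccc(O)cc1`: > 250 ug/mL
compound 2, `CCCc1ccc(C2NC(=S)NC(C)=C2C(=O)OCC)cc1`: 22.5 ug/mL
compound 3, `CCCc1ccc(C2NC(=O)NC(C)=C2C(=O)OCC)cc1`: 49.7 ug/mL

In a functional assay on NCI-H460 cells (Homo sapiens) for inhibition, read by sulforhodamine B assay, with a stated time of 48 h (on this read-out lower numbers stand for stronger inhibition of growth and higher numbers for weaker inhibition of growth), compound 2 gives 22.5 ug/mL. Compound 3 gives 49.7 ug/mL in this assay, the higher of the two numbers that are actual numbers. How the core of compound 3 differs from the core of compound 2 is not broken down here. The value of compound 1 in this assay is a limit of the assay, > 250 ug/mL, and not a number.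

The change from compound 2 to compound 1 is hydroxy in place of propyl on an aromatic carbon. It made an at least 11-fold higher number from compound 2 to compound 1 (1.04 log units; beyond the scatter). The size of that step is known only as a lower bound because the limit of > 250 ug/mL in this assay, at which 1 of the 3 values shown sits, caps what the assay can report for compound 1.

Compound 4, `CCOC(=O)C1=C(C)NC(=O)NC1c1ccc(O)cc1`, has not yet been measured in this assay. It differs from compound 3 by hydroxy in place of propyl on an aromatic carbon. The place of the change is described in the same words as for the change from compound 2 to compound 1, so this is the same change made on the other core. Since compound 3 starts from a higher number than compound 2, and the earlier change made an at least 11-fold higher number from compound 2 to compound 1 (1.04 log units; beyond the scatter), a step of similar or larger size is expected from compound 3 to compound 4, an 8.0-fold higher number from compound 3 to compound 4 (0.91 log units; beyond the scatter). Compound 4 is therefore expected to give 400 ug/mL in this assay, with a plausible range from 150 ug/mL to 1200 ug/mL, and most likely to be reported only as a limit.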

Compound 4, concentration for 50% growth inhibition: 40.6 ug/mL
Compound 4: middle estimate off by 9.9-fold (0.99 log units), on the high side; the whole stated range lies above it.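

In this assay, placing hydroxy in place of propyl on the aromatic carbon gives a 1.2-fold lower number from compound 3 to compound 4 (0.09 log units; within the scatter), so the change does not carry its effect over from the core of compound 2 to the core of compound 3: the same change on two cores in this assay, an at least 11-fold higher number (1.04 log units; beyond the scatter) from compound 2 to compound 1 and a 1.2-fold lower number (0.09 log units; within the scatter) from compound 3 to compound 4, at least 13-fold (1.13 log units) apart, beyond the scatter of two such steps

Compound 1 stands at a limit of the assay and not at a number, so the earlier step is known only as a lower bound: the limit of > 250 ug/mL in this assay, at which 1 of the 4 values shown sits.

The two pairs show that in this series the outcome of this one change depends on the core it is made on, but they do not show what in the cores sets the outcome apart, and two pairs give no rule for any further core.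

The compounds shown leave open how an amine, a methoxy group or a longer chain such as butyl, in place of propyl on the same aromatic carbon, would read on either core, and whether such groups would also separate the two cores. They also leave open whether a carboxylic acid in place of the ethyl ester would alter the picture on either core.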